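The source may report more compounds than this note shows. Statements on the series, on what has been measured and on what is new or still open speak of the compounds shown alone.

Three compounds in this series have numbers in a functional assay on Caco-2 cells (Homo sapiens) for activation, read by fluorescence, tested at 1 uM; on this read-out higher numbers stand for a weaker effect at the one concentration tested and lower numbers for a stronger effect. Compound 1 `COc1cc(/C=C/C2=CC(=O)CC(c3ccc(O)c(OC)c3)N2CCCO)ccc1O` gives 95.6%. Compound 2 `COc1cc(/C=C/C(=O)/C=C(/C=C/c2ccc(O)c(OC)c2)NCCO)ccc1O` gives 103% in this assay. Compound 3 `COCCNC(=C\C(=O)/C=C/c1ccc(O)cc1)/C=C/c1ccc(O)cc1` gives 94.9% in this assay. All three numbers lie within the usual scatter of one another, so compound 3 stands level with compounds 1 and 2 on the read-out shown, and none of the three is set apart.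

Compound 4 `COCCCNC(=C\C(=O)/C=C/c1ccc(O)cc1)/C=C/c1ccc(O)cc1` has not yet been measured in this assay. It differs from compound 3 in one place: methoxymethyl in place of methoxy on a saturated chain carbon, two bonds along the chain from an amine nitrogen. Within the data shown here, no pair of measured compounds shows a step of this kind, so there is no measured precedent for its size. The expected step is a number 1.1 percentage points higher from compound 3 to compound 4 (within the scatter), that is, nothing beyond the scatter in either direction. Compound 4 is estimated to give 96% in this assay, within 86% to 106%.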

Compound 4, a percentage reported as activity, at one concentration (the size of the read-out at that concentration, not a potency): 97%
For compound 4 the middle estimate is 1 percentage points below the measured one, and the stated range covers the measured number.
By their numbers in this assay, from the lowest: compounds 3, 1, 4 and 2 (each within the scatter of the next).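

In this assay, among these compounds, (3-methoxypropyl)amino in place of (2-methoxyethyl)amino gives a number 2.1 percentage points higher from compound 3 to compound 4 (within the scatter), the first step that can be read at one place. On a saturated chain carbon, two bonds along the chain from an amine nitrogen, methoxymethyl in place of methoxy therefore leaves the read-out within the scatter. No measurement at hand speaks to why this is so.

As far as these compounds go, whether a carboxylic acid, a morpholine or a longer chain at this place would move the number beyond the scatter stays open. One concentration also leaves potency unresolved.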